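A few compounds are considered here, and "the series" means these few. Any claim that something is new, unique, unknown or untested is made for them only; others in the source may bear on it.

Compound 1 (`CC(=O)N1CCC(C(=O)N2CCC(N3CCN(C(=O)c4cc(-c5ccc(C)cc5)nc(-c5ccc(C)cc5)c4)CC3)CC2)CC1`) : 343 nM
Compound 2 (`CCCC(=O)N1CCC(N2CCN(C(=O)c3c(NC(=O)NCC)sc4ccccc34)CC2)CC1`) : "not determined" (no result reported)

Both compounds were taken into a functional assay on HepG2 cells (Homo sapiens) for inhibition, read by scintillation counting, with a stated time of 2 h (a lower number here means a stronger inhibitor, a higher number a weaker inhibitor), but only one gave a usable result. Compound 2 has no number to stand on, and its entry reads "not determined" (no result reported) so it cannot be ranked against compound 1.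

Compound 3 (`CCNC(=O)Nc1sc2ccccc2c1C(=O)N1CCN(C2CCN(C(=O)C3CCCC3)CC2)CC1`) keeps the rest of compound 2 and alters a single place. The change reads cyclopentyl in place of propyl on a carbonyl carbon with cyclopentyl in place of propyl on a carbonyl carbon.

Within the data shown here, no measured step shows what such a swap does, so no direction can be favoured in this assay and a step no larger than the scatter is expected. Among the measured compounds shown here, the only numerical anchor is compound 1 at 343 nM and it is a loose one, since its structure is quite different. For compound 3 the estimated value is 300 nM with an expected range from 50 nM to 1500 nM as a wide allowance.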

Compound 3, half-maximal inhibitory concentration: 309 nM
Compound 3: middle estimate off by 1.0-fold (0.01 log units), on the low side; the range from low to high includes it.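

In this assay compound 3 gives 309 nM but compound 2 has no number to set against it, so no step can be read between them. Going by these compounds, whether cyclopentyl in place of propyl strengthens or weakens inhibition stays open. No evidence at hand bears on this result.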